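The source may hold more compounds than are shown below. What is called first, only, known or untested is meant among the compounds shown, and "the series" means these compounds.

Measured compounds in a functional assay on HCT-15 cells (Homo sapiens) for inhibition, read by sulforhodamine B assay, with a stated time of 48 h; a higher number here means a weaker inhibitor of growth, a lower number a stronger inhibitor of growth:
compound 1, `N#C/C(=C\N1CCN(C(=O)c2ccco2)C1=S)C(=O)Nc1ccc(Cl)cc1`: 21300 nM
compound 2, `N#C/C(=C\N1CCN(C(=O)c2ccco2)C1=S)C(N)=O`: 3800 nM

Compound 2 gives the lowest of the two numbers in this assay. Within the data shown here, its nearest neighbour is compound 1, and the one measured step is a 5.6-fold lower number from compound 1 to compound 2 (0.75 log units; beyond the scatter), hydrogen in place of 4-chlorophenyl on an amide-type nitrogen; removing the aryl substituent from the carbamoyl group thus gave the stronger growth inhibitor.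

Compound 3, `N#C/C(=C\N1CCN(C(=O)c2ccco2)C1=S)C(=O)c1ccccc1`, is not yet measured in this assay. It differs from compound 2 by phenyl in place of amino on a carbonyl carbon, which, cut one bond further out, reads carbamoyl to benzoyl. Among the measured compounds shown here, the only step that bears on this is the one from compound 1 to compound 2, which also concerns the carbamoyl group: there, presence of an aryl ring on that group went with the weaker inhibitor. The change to compound 3 again introduces an aryl ring on the same group, though on the carbonyl carbon rather than on the nitrogen, and removes the hydrogen-bond donor. A move back towards higher numbers, of a size somewhat smaller than that step, is expected. Compound 3 is therefore estimated at 9000 nM, with a range of 3000 nM to 30000 nM. For compound 3 the expected step is a 2.4-fold higher number from compound 2 to compound 3 (0.37 log units; beyond the scatter).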

Compound 3, concentration for 50% growth inhibition: 5700 nM
Beside the measured number, compound 3's estimate is 1.6-fold (0.20 log units) above it, and the stated range covers the measured number.
By their numbers in this assay, from the lowest: compounds 2 and 3 (each within the scatter of the next); then compound 1.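

In this assay the change from amino to phenyl on a carbonyl carbon gives (a 1.5-fold higher number from compound 2 to compound 3 (0.18 log units; within the scatter)), so this position accepts the swap from carbamoyl to benzoyl, with the loss of a hydrogen-bond donor and the entry of an aromatic ring, without a separation between the two compounds. An aryl ring on this carbonyl group therefore does not by itself go with the higher number seen for compound 1, as the earlier step alone might have suggested. The second new step (a 3.7-fold lower number from compound 1 to compound 3 (0.57 log units; beyond the scatter)), phenyl in place of (4-chlorophenyl)amino on a carbonyl carbon, places the difference in the (4-chlorophenyl)amino group as a whole, and no measurement offered here explains the difference.

Still open, on these data alone, is whether the higher number of compound 1 follows the chlorine or the nitrogen that joins the ring to the carbonyl carbon, which a plain phenylamino group on this carbonyl carbon would help to separate. Also open, as far as these compounds go, is how a methyl group, a longer alkyl chain or a dimethylamino group on the same carbonyl carbon would read in this assay.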